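Thiophen-3-yl to Furan-2-yl: an Expected Small Step

This account rests on a few compounds, and the source may have more. Where it says the series, first, only, none or still open, it means among the compounds named here.

Compound 1 `O[C@@H]1Cc2ccccc2[C@H]1NC1CCN(CCCc2c[nH]c3ccc(-n4cnnc4)cc23)CC1` gives 6.6 nM in an assay on CHO cells for displacement of a labelled ligand from 5-hydroxytryptamine receptor 1D (Homo sapiens); a lower number here means a stronger inhibitor, a higher number a weaker inhibitor.
Compound 2 `CN(Cc1ccsc1)C1CCN(CCCc2c[nH]c3ccc(-n4cnnc4)cc23)CC1` gives 1.5 nM in this assay.

Within the data shown here, of the two compounds measured, compound 2 has the lower number in this assay, and the only other measured compound, compound 1, sits clearly higher: a 4.4-fold lower number from compound 1 to compound 2 (0.64 log units; beyond the scatter). That step, however, exchanges the whole amine substituent on the saturated ring carbon and says nothing about small changes within the thiophene-bearing group itself.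

Compound 3 `CN(Cc1ccco1)C1CCN(CCCc2c[nH]c3ccc(-n4cnnc4)cc23)CC1` keeps everything in compound 2 except one ring: furan-2-yl in place of thiophen-3-yl on a saturated chain carbon bound to an amine nitrogen. Both rings are five-membered aromatic rings with one hetero atom, and the counts of donors, acceptors and charge are unchanged, so the exchange is a modest one on paper. Among the measured compounds shown here, no measured pair here tests this kind of swap, so there is no step to lean on; the single known step between compound 1 and compound 2 concerns a different part of the molecule.

With nothing indicating a shift, compound 3 is expected to land close to compound 2, estimated at 2 nM with a range of 0.7 nM to 6 nM. The step this estimate implies is a 1.3-fold higher number from compound 2 to compound 3 (0.12 log units; within the scatter), which is expected to stay within the usual scatter.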

Compound 3, half-maximal inhibitory concentration: 9.3 nM
Compound 3: middle estimate off by 4.7-fold (0.67 log units), on the low side; measured number outside the range, above it.
By their numbers in this assay, from the lowest: compound 2; then compounds 1 and 3 (each within the scatter of the next).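

In this assay, the ring on a saturated chain carbon bound to an amine nitrogen turns out to be sensitive to a change that looks small on paper: furan-2-yl in place of thiophen-3-yl gives a 6.2-fold higher number from compound 2 to compound 3 (0.79 log units; beyond the scatter), although the heavy-atom, donor, acceptor and charge counts all stay the same. The step to compound 3 from the other side reads a 1.4-fold higher number from compound 1 to compound 3 (0.15 log units; within the scatter), so the clear edge that compound 2 holds over compound 1 does not survive this ring swap. Nothing available here accounts for the gap between the two rings.

The swap also changes two things at once, sulfur becoming oxygen and the ring's point of attachment going from 3-yl to 2-yl, so the compounds shown cannot say which of the two matters. A thiophen-2-yl or a furan-3-yl group would pull these apart, since each changes only one of the two, while a phenyl ring would show whether a hetero atom in this ring is needed at all.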